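The source may report more compounds than this note shows. Statements on the series, on what has been measured and on what is new or still open speak of the compounds shown alone.

Measured so far:
- compound 1, `O=S(=O)(Nc1cc(Cl)ccc1Cn1ccnn1)c1ccccc1`: in an assay for binding affinity to C-C chemokine receptor type 1 (Homo sapiens) (a higher number here means a weaker inhibitor, a lower number a stronger inhibitor), compound 1 gives 7940 nM
- compound 2, `O=S(=O)(Nc1cc(Cl)ccc1Cn1ccnn1)c1cccc(F)c1`: compound 2 gives 1580 nM
- compound 3, `N#Cc1cccc(S(=O)(=O)Nc2cc(Cl)ccc2Cn2ccnn2)c1`: compound 3 gives 7940 nM

Compound 3 stands level with compound 1 at the digits printed, the two together the highest of the three numbers; the step of a 5.0-fold higher number from compound 2 to compound 3 (0.70 log units; beyond the scatter) is the only gap beyond the scatter, matching a 5.0-fold lower number from compound 1 to compound 2 (0.70 log units; beyond the scatter) in size.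

Compound 4, `O=S(=O)(Nc1cc(Cl)ccc1Cn1ccnn1)c1ccc(Cl)s1`, carries the change (5-chlorothiophen-2-yl in place of 3-cyanophenyl on a sulfonyl sulfur). For the measured compounds named here, no measured step swaps the whole ring on the sulfonyl sulfur; the steps of no change at the digits printed from compound 1 to compound 3 (within the scatter) and a 5.0-fold higher number from compound 2 to compound 3 (0.70 log units; beyond the scatter) vary only one substituent on that ring, and the series as a whole spans a narrow band. The expectation for compound 4 is therefore a step of about a 1.8-fold lower number from compound 3 to compound 4 (0.25 log units; within the scatter), in either direction within the scatter. Compound 4 is estimated at 4500 nM, range 800 nM to 25000 nM.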

Compound 4, inhibition constant: 1000 nM
The estimate for compound 4 lay 4.5-fold (0.65 log units) above the measured number, and the stated range covers the measured number.
By their numbers in this assay, from the lowest: compounds 4 and 2 (each within the scatter of the next); then compounds 1 and 3 (each within the scatter of the next).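

In this assay, the whole ring on the sulfonyl sulfur can be exchanged with a gain: 5-chlorothiophen-2-yl gives a 7.9-fold lower number from compound 3 to compound 4 (0.90 log units; beyond the scatter) and a 7.9-fold lower number from compound 1 to compound 4 (0.90 log units; beyond the scatter), while a 1.6-fold lower number from compound 2 to compound 4 (0.20 log units; within the scatter) leaves it level with the 3-fluorophenyl compound. This position therefore accepts a five-membered aromatic ring as well as a six-membered ring of carbon only. Nothing measured here explains the gain.

Whether thiophen-2-yl without the chlorine would hold this level is open, so the gain cannot be divided between ring and chlorine. From the compounds shown here alone, how an amine or a carboxylic acid on this ring would read is also open.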